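Trifluoromethyl on the Anilide Ring of a Thiocarbamate Series

The source may hold more compounds than are shown below. What is called first, only, known or untested is meant among the compounds shown, and "the series" means these compounds.

Among the compounds with values here, the three compounds measured so far share one core and differ only in the group on the anilide ring. Compound 1 `Cc1cccc(NC(=O)CSC(=S)N[C@H]2CCOC2=O)c1` carries a methyl group. In a functional assay on SMMC-7721 cells (Homo sapiens) for cytotoxicity, read by MTT assay, with a stated time of 72 h (on this read-out higher numbers stand for weaker inhibition and lower numbers for stronger inhibition), compound 1 gives > 128000 nM, which is a limit of the assay rather than a number. Compound 2 `O=C(CSC(=S)N[C@H]1CCOC1=O)Nc1cccc(Cl)c1` carries a chloro group in the same place. In this assay compound 2 gives > 128000 nM, again a limit. Compound 3 `O=C(CSC(=S)N[C@H]1CCOC1=O)Nc1ccccc1` carries hydrogen there. In this assay compound 3 gives > 128000 nM, also a limit. Because all three values sit at the same limit (the limit of > 128000 nM in this assay, at which 3 of the 3 values shown sit), no one of them can be placed against the others.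

Compound 4 `O=C(CSC(=S)N[C@H]1CCOC1=O)Nc1cccc(C(F)(F)F)c1` differs from compound 3 by trifluoromethyl in place of hydrogen on an aromatic carbon. The measured steps that bear on changing this ring position are a step that the two limits leave unreadable from compound 1 to compound 3, a step that the two limits leave unreadable from compound 2 to compound 3 and a step that the two limits leave unreadable from compound 1 to compound 2; none of them has a readable size, so a methyl, a chloro or a hydrogen at this position all leave the compound outside the measurable range.

The step from compound 3 to compound 4 is therefore expected to be a step that the limit leaves unreadable from compound 3 to compound 4, that is, no readable change. Compound 4 is estimated to give 150000 nM in this assay, with a range from 60000 nM to 400000 nM, and most likely only a limit will be reported.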

Compound 4, half-maximal inhibitory concentration: > 128000 nM
Compound 4 gave a limit, no number (the forecaster's own chance of this, stated with the estimate: 80%); the middle value does not contradict the limit.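

In this assay compound 4 gives > 128000 nM, which is a limit and not a number. Its steps from compound 1, compound 2 and compound 3 cannot be read, as all four compounds share one limit: the limit of > 128000 nM in this assay, at which 4 of the 4 values shown sit.

The compounds shown leave open how strongly any of them inhibits these cells, and whether any group at this ring position gives a measurable value.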